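Hydrazone nitrogen substituents on the shared core

A few compounds are considered here, and "the series" means these few. Any claim that something is new, unique, unknown or untested is made for them only; others in the source may bear on it.

Measured so far:
compound 1 `COc1ccc(/C(=N\N)c2ccc3c(ccn3C)c2)c(OC)c1OC`: 2000 nM
compound 2 `COc1ccc(/C(=N\NC(C)=O)c2ccc3c(ccn3C)c2)c(OC)c1OC`: 2000 nM

In a functional assay on HT-29 cells (Homo sapiens) for cytotoxicity, read by XTT assay, with a stated time of 72 h (on this read-out lower numbers stand for stronger inhibition and higher numbers for weaker inhibition), compound 1 gives 2000 nM and compound 2 gives 2000 nM. Among the compounds with values here, the one step between them, acetyl in place of hydrogen on an amine nitrogen, reads no change at the digits printed from compound 1 to compound 2 (within the scatter). Compound 2 therefore stands level with compound 1 at the digits shown, and the pair gives no sign that the substituent on that nitrogen moves the read-out.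

Compound 3 `CN/N=C(/c1ccc2c(ccn2C)c1)c1ccc(OC)c(OC)c1OC` is the next member. Relative to compound 2 the change is methyl in place of acetyl on an amine nitrogen, the same nitrogen that carried the hydrogen-to-acetyl step. Within the data shown here, only that step bears on the new change, and it was flat within the scatter. With hydrogen and acetyl level on this nitrogen, a methyl there is not expected to move the number beyond the scatter either, so the expected step from compound 2 to compound 3 in this assay is no change at the digits printed from compound 2 to compound 3 (within the scatter). Compound 3 is accordingly estimated at 2000 nM, with an expected range from 1000 nM to 4000 nM.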

Compound 3, half-maximal inhibitory concentration: 2000 nM
For compound 3 middle estimate and measured number coincide at the digits printed; the range from low to high includes it.
By their numbers in this assay, from the lowest: compounds 1, 2 and 3 (each within the scatter of the next).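

In this assay this nitrogen has now carried hydrogen, acetyl and methyl, and the three cannot be told apart: methyl in place of acetyl reads no change at the digits printed from compound 2 to compound 3 (within the scatter) and methyl in place of hydrogen reads no change at the digits printed from compound 1 to compound 3 (within the scatter) on the same scale. Within the data shown here, until now the only change at this position was hydrogen to an acyl group; these steps add a simple alkyl group and show that, for compounds 1, 2 and 3, neither the presence of the acetyl carbonyl nor the swap between acetyl and the smaller methyl registers in this read-out. No supporting data bear on why the position stays flat across these three substituents.

Open, as far as these compounds go, is whether the flat reading holds for substituents well beyond these three, such as a longer alkyl chain, a benzoyl group, or a chain ending in a carboxylic acid or an amine. Also open, from the compounds shown here alone, is whether these same nitrogen changes stay flat when the shared core is altered elsewhere, since all three compounds keep it unchanged.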